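Replacing a hydroxy with fluoro in a growth-inhibition series

The compounds below may be only part of what the source reports. "The series", "measured", "known", "first", "only" and "open" are said of these compounds alone.

Values measured so far in a functional assay on KM12 cells (Homo sapiens) for inhibition (on this read-out higher numbers stand for weaker inhibition of growth and lower numbers for stronger inhibition of growth), are as follows.

- Compound 1 `COc1ccc(-n2cnnc2-c2cc(OC)c(OC)c(OC)c2)cc1` gives 2140 nM
- Compound 2 `COc1cc(-c2nncn2-c2ccc(N(C)C)cc2)cc(OC)c1OC` gives 26.3 nM
- Compound 3 `COc1ccc(-n2cnnc2-c2cc(OC)c(OC)c(OC)c2)cc1O` gives 141 nM

Compound 3 stands in the middle of these numbers, higher than compound 2 and lower than compound 1. Compound 4 `COc1ccc(-n2cnnc2-c2cc(OC)c(OC)c(OC)c2)cc1F` differs from compound 3 by fluoro in place of hydroxy on an aromatic carbon, ortho to a methoxy group and meta to a large group.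

The closer of the two measured steps is a 15-fold lower number from compound 1 to compound 3 (1.18 log units; beyond the scatter) and it came with hydroxy in place of hydrogen on an aromatic carbon, the same carbon that changes here. The other step is an 81-fold lower number from compound 1 to compound 2 (1.91 log units; beyond the scatter) and it came with dimethylamino in place of methoxy on an aromatic carbon, so it concerns another group and bears less on this change.

Among the compounds with values here, no measured compound carries fluoro, so the size remains uncertain. Part of the gain seen with compound 3 is expected to be lost, giving a moderately higher number. The estimate means a 3.5-fold higher number from compound 3 to compound 4 (0.55 log units; beyond the scatter) as the expected change in this assay for this replacement. Compound 4 is estimated at 500 nM (expected range 110 nM to 2300 nM).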

Compound 4, concentration for 50% growth inhibition: 1450 nM
The estimate for compound 4 lay 2.9-fold (0.46 log units) below the measured number, within the range that was stated.
By their numbers in this assay, from the lowest: compound 2; then compound 3; then compounds 4 and 1 (each within the scatter of the next).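

In this assay, fluoro does not stand in for hydroxy at this carbon: the replacement gives a 10-fold higher number from compound 3 to compound 4 (1.01 log units; beyond the scatter) and so gives up the gain that compound 3 held over compound 1. Fluoro in place of hydrogen on the same carbon gives a 1.5-fold lower number from compound 1 to compound 4 (0.17 log units; within the scatter) and stays within the usual scatter, so compound 4 cannot be told apart from compound 1 in this read-out, and the gain is tied to hydroxy rather than to any group placed here. The material given offers nothing that accounts for this difference between hydroxy and fluoro.

The compounds shown leave open whether an amine or a carboxylic acid on this carbon would keep the gain seen with hydroxy. They also leave open whether hydroxy here would add to the effect of the dimethylamino group of compound 2 when both are present.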